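Halogen swap on the aryl thiosemicarbazone: compound 1 to compound 3

This account rests on a few compounds, and the source may have more. Where it says the series, first, only, none or still open, it means among the compounds named here.

For the measured compounds named here, compound 1 `S=C(N/N=C/c1ccc2ccccc2n1)Nc1cccc(Cl)c1` is the one member of this series with a numerical read-out so far. In a functional assay on SGC-7901 cells (Homo sapiens) for antiproliferative activity, read by sulforhodamine B assay, with a stated time of 72 h (on this read-out higher numbers stand for weaker inhibition and lower numbers for stronger inhibition), compound 1 gives 61300 nM. Compound 2 `Cc1ccc(NC(=O)N/N=C/c2ccc3ccccc3n2)cc1` returns only a limit of the assay in this assay, > 100000 nM. The measured picture is thus a single number set against (the limit of > 100000 nM in this assay, at which 1 of the 2 values shown sits), and no comparison between two fully measured compounds is available.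

Compound 3 `S=C(N/N=C/c1ccc2ccccc2n1)Nc1ccccc1Br` has not yet been tested in this assay. It differs from compound 1 in one place: 2-bromophenyl in place of 3-chlorophenyl on an amide-type nitrogen. The substituent keeps the same size and count of heavy atoms, and the shared core and the thiocarbonyl link are untouched.

Going by the values given here, with no measured step to calibrate against, the change is expected to shift the read-out by no more than the usual scatter, with no firm direction; the step from compound 1 to compound 3 is estimated as a 1.1-fold lower number from compound 1 to compound 3 (0.05 log units; within the scatter). For compound 3 the expected value in this assay is 55000 nM, with a range from 18000 nM to 160000 nM.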

Compound 3, half-maximal inhibitory concentration: > 100000 nM
Compound 3: only a limit was reported; the forecaster's own chance of this, stated with the estimate: 30%; middle value at least 1.8-fold (0.25 log units) away from the limit.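

For the compounds shown here, at the amide-type nitrogen, 2-bromophenyl in place of 3-chlorophenyl gives an at least 1.6-fold higher number from compound 1 to compound 3 (0.21 log units; that floor lies within the scatter) and so provides the first readable step, though only as a floor. The value for compound 3 is a limit of the assay and not a number, so the step has no upper end, and its floor alone does not separate compound 3 from compound 1 beyond the usual scatter. Compound 1 remains the only compound shown with a numerical read-out, and the rest of the series stands at the limit: the limit of > 100000 nM in this assay, at which 2 of the 3 values shown sit.

The compounds shown leave open whether the read-out of compound 1 depends on the chlorine itself or on where the halogen sits on the phenyl ring, as 3-chlorophenyl and 2-bromophenyl differ in both at once. Also open, from the compounds shown here alone, is how an amine or a carboxylic acid on that phenyl ring, or a longer chain in its place on the amide-type nitrogen, would read in this assay.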